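This account rests on a few compounds, and the source may have more. Where it says the series, first, only, none or still open, it means among the compounds named here.

Measured compounds:
Compound 1, `CCSC[C@H](NC(C)=O)C(=O)CCl`: 52800 nM
Compound 2, `CCCCSC[C@H](NC(C)=O)C(=O)CCl`: 41400 nM

Going by the values given here, in a functional assay on NALM-6 cells (Homo sapiens) (a higher number here means a weaker inhibitor, a lower number a stronger inhibitor), compound 2 gives the lowest of the two numbers measured so far, though its nearest neighbour, compound 1, stands only a step away that is within the scatter, as the change a 1.3-fold lower number from compound 1 to compound 2 (0.11 log units; within the scatter) shows. The two compounds therefore cannot be ranked against each other on these data.

Compound 3, `CCCCCCSC[C@H](NC(C)=O)C(=O)CCl`, differs from compound 2 by ethyl in place of hydrogen on a saturated chain carbon, four bonds along the chain from a sulfur. Among the compounds with values here, the only measured step that bears on this change is the one from compound 1 to compound 2, where the same kind of chain extension, cut two bonds nearer the sulfur, produced a 1.3-fold lower number from compound 1 to compound 2 (0.11 log units; within the scatter) and so did not move the number beyond the scatter. With nothing else to go on, a further extension of the same chain is expected to behave alike: compound 3 is estimated to give 35000 nM in this assay, between 15000 nM and 80000 nM. The step from compound 2 to compound 3 is thus expected to be a 1.2-fold lower number from compound 2 to compound 3 (0.07 log units; within the scatter), which is no change beyond the scatter.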

Compound 3, half-maximal inhibitory concentration: 3300 nM
Compound 3: the middle estimate sits 11-fold (1.03 log units) above what was measured; the whole stated range lies above it.
By their numbers in this assay, from the lowest: compound 3; then compounds 2 and 1 (each within the scatter of the next).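

In this assay, this position answers to the change far more strongly than the earlier pair suggested: ethyl in place of hydrogen four bonds along the chain from a sulfur gives a 13-fold lower number from compound 2 to compound 3 (1.10 log units; beyond the scatter), while the same group two bonds along the chain gave a 1.3-fold lower number from compound 1 to compound 2 (0.11 log units; within the scatter) and no change beyond the scatter. Read as a single change, butyl in place of hydrogen two bonds along the chain from a sulfur gives a 16-fold lower number from compound 1 to compound 3 (1.20 log units; beyond the scatter), so among these three compounds the response to chain length is not gradual: compound 1 and compound 2 cannot be told apart, and only compound 3 separates from them. Nothing available explains why the number responds to the chain at this length and not before.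

The compounds shown leave open whether a longer chain would lower the number further, hold it or raise it again, as three compounds cannot show where this trend ends. They also leave open whether the chain's length alone matters, or whether a chain ending in an amine, a carboxylic acid or a phenyl ring would give a similar number.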